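This account rests on a few compounds, and the source may have more. Where it says the series, first, only, none or still open, it means among the compounds named here.

Compound 1 `COc1ccc(-c2c(Nc3ccc(C)c(O)c3)c3ccc(OC)cc3oc2=O)cc1`: 26500 nM
Compound 2 `COc1ccc(-c2c(Nc3ccc(C)cc3)c3ccc(OC)cc3oc2=O)cc1`: 82400 nM
Compound 3 `COc1ccc(-c2c(Nc3cccc(C(F)(F)F)c3)c3ccc(OC)cc3oc2=O)cc1`: not yet measured

Within the data shown here, in a functional assay on HCT-116 cells (Homo sapiens) for antiproliferative activity, read by MTT assay, with a stated time of 48 h (on this read-out lower numbers stand for stronger inhibition and higher numbers for weaker inhibition), compound 2 gives 82400 nM as the higher of the two numbers so far. Compound 3 carries 3-(trifluoromethyl)phenyl in place of 4-methylphenyl on a nitrogen on an aromatic ring. Among the measured compounds shown here, only one measured step bears on this, and only indirectly: a 3.1-fold higher number from compound 1 to compound 2 (0.49 log units; beyond the scatter) (hydrogen in place of hydroxy on an aromatic carbon). That modest step shows that a change within the group that leaves here can move the number beyond the scatter. For the measured compounds named here, no measured step involves the trifluoromethyl group, so the direction is weakly supported. A modest step to a lower number is expected in this assay (the expected step is a 2.4-fold lower number from compound 2 to compound 3 (0.37 log units; beyond the scatter)). For compound 3 the estimate is 35000 nM with an expected range from 10000 nM to 120000 nM (an expectation only).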

Compound 3, half-maximal inhibitory concentration: 41200 nM
Compound 3: middle estimate off by 1.2-fold (0.07 log units), on the low side; measured number inside the range.
By their numbers in this assay, from the lowest: compounds 1, 3 and 2 (each within the scatter of the next, the first and the last beyond it).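

In this assay, the exchange on the nitrogen gives a 2.0-fold lower number from compound 2 to compound 3 (0.30 log units; within the scatter), so 3-(trifluoromethyl)phenyl and 4-methylphenyl cannot be told apart at this position. The second comparison gives a 1.6-fold higher number from compound 1 to compound 3 (0.19 log units; within the scatter): a ring without hydroxy can read the same as 3-hydroxy-4-methylphenyl within the scatter, so the earlier hydroxy step does not show that a hydroxy group is needed at this position to reach the number of compound 1. Nothing measured here accounts for these results.

The exchange alters both the group and where it sits on the ring, and a 3-methylphenyl or a 4-(trifluoromethyl)phenyl on the nitrogen would separate the two. From the compounds shown here alone, how an amine or a carboxylic acid on this ring would read also remains open.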